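This account rests on a few compounds, and the source may have more. Where it says the series, first, only, none or still open, it means among the compounds named here.

Working notes on the series. Compound 1, `CCCCCCCCCO[C@@H]1[C@@H](N)[C@@H](OCC(O)CNCCCO)O[C@H](CN)[C@H]1OCCCCCCCCC`, is the reference point; in a toxicity assay on the whole organism (J774 cells) for cytotoxicity, with Mus musculus as the target, read by MTT assay, with a stated time of 24 h, tested at 30 uM (a lower number here means a stronger effect, a higher number a weaker effect of the compound at the concentration tested), compound 1 gives 13.7%, and on the numbers shown it stands together with compound 2 rather than apart from it. Compound 2, `CCCCCCCCCO[C@@H]1[C@@H](N)[C@@H](OCC(O)CO)O[C@H](CN)[C@H]1OCCCCCCCCC`, carries hydroxy in place of (3-hydroxypropyl)amino on a saturated chain carbon, two bonds along the chain from an oxygen on a saturated carbon; in this assay compound 2 gives 8.8%, and the step of a number 4.9 percentage points lower from compound 1 to compound 2 (within the scatter) lies within the scatter.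

Compound 3, `CCCCCCCCCO[C@@H]1[C@@H](N)[C@@H](OC[C@@H](O)CN)O[C@H](CN)[C@H]1OCCCCCCCCC`, differs from compound 1 by 2-amino-1-hydroxyethyl in place of 1-hydroxy-2-((3-hydroxypropyl)amino)ethyl on a saturated chain carbon bound to an oxygen on a saturated carbon. Within the data shown here, the one measured step that bears on this change is a number 4.9 percentage points lower from compound 1 to compound 2 (within the scatter), which altered the same side chain and moved this assay by an amount within the scatter. For compound 3 no step beyond the scatter is therefore expected, and the estimated step is a number 1.7 percentage points lower from compound 1 to compound 3 (within the scatter). Compound 3 is expected to give 12% in this assay, within a range from 3% to 25%.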

Compound 3, a percentage reported as activity, at one concentration (the size of the read-out at that concentration, not a potency): 7.2%
Compound 3: middle estimate off by 4.8 percentage points, on the high side; the measured number falls inside the stated range.
By their numbers in this assay, from the lowest: compounds 3, 2 and 1 (each within the scatter of the next).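

In this assay, 2-amino-1-hydroxyethyl in place of 1-hydroxy-2-((3-hydroxypropyl)amino)ethyl gives a number 6.5 percentage points lower from compound 1 to compound 3 (within the scatter) and so does not separate the shorter side chain from the longer one. 2-amino-1-hydroxyethyl in place of 1,2-dihydroxyethyl gives a number 1.6 percentage points lower from compound 2 to compound 3 (within the scatter) and so does not separate the amine-bearing side chain from the diol, leaving compounds 1, 2 and 3 unresolved from one another at this place. No measurement shown here bears on why these three side chains cannot be told apart.

As far as these compounds go, what remains open is whether a carboxylic acid or a guanidine in place of 2-amino-1-hydroxyethyl at this place would move the read-out beyond the scatter. The effect of the stereocentre in 2-amino-1-hydroxyethyl also remains open, since its opposite configuration is not among the compounds shown.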